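The source may hold more compounds than are shown below. What is called first, only, known or untested is meant among the compounds shown, and "the series" means these compounds.

Of the compounds shown here, three sharing one core have been read in an ADME assay on Vero cells (Chlorocebus sabaeus) for cytotoxicity, read by MTT assay; a higher number here means a weaker inhibitor, a lower number a stronger inhibitor: compound 1 (`CCC(CC)C(=O)OCC(C)(C)CC1=C(O)C(=O)c2ccccc2C1=O`) gives 104000 nM, compound 2 (`CCCC(C)C(=O)OCC(C)(C)CC1=C(O)C(=O)c2ccccc2C1=O`) gives 120 nM, and compound 3 (`CCCCCCC(=O)OCC(C)(C)CC1=C(O)C(=O)c2ccccc2C1=O`) gives 99300 nM. Compound 3 thus stands level with one neighbour, a 1.0-fold lower number from compound 1 to compound 3 (0.02 log units; within the scatter), and far from the other, an 830-fold higher number from compound 2 to compound 3 (2.92 log units; beyond the scatter). Compound 4 (`CCCCCCC(C)C(=O)OCC(C)(C)CC1=C(O)C(=O)c2ccccc2C1=O`) differs from compound 3 on a carbonyl carbon, where 1-methylheptyl replaces hexyl (1-methylheptyl in place of hexyl on a carbonyl carbon). The nearest guide is compound 2, whose 1-methylbutyl shares the 1-methyl branch of the new group and which sits apart from the hexyl compound by that large step. Compound 1 goes against reading this as a rule for branching, since its pentan-3-yl gives no such drop: an 870-fold lower number from compound 1 to compound 2 (2.94 log units; beyond the scatter) separates it from compound 2. With two branched groups pointing in opposite ways, a moderate move towards a lower number is expected, held with wide uncertainty, a 9.9-fold lower number from compound 3 to compound 4 (1.00 log units; beyond the scatter). For compound 4 the estimate is 10000 nM, with an expected range from 300 nM to 110000 nM.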

Compound 4, half-maximal inhibitory concentration: 450 nM
The estimate for compound 4 lay 22-fold (1.35 log units) above the measured number, and the stated range covers the measured number.
By their numbers in this assay, from the lowest: compound 2; then compound 4; then compounds 3 and 1 (each within the scatter of the next).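

In this assay the 1-methyl branch now appears with two chain lengths, and the drop seen with compound 2 is not confined to 1-methylbutyl: 1-methylheptyl in place of hexyl gives a 220-fold lower number from compound 3 to compound 4 (2.34 log units; beyond the scatter) on the same carbonyl carbon. The longer branched group gives back only a small part of that gain, with a 3.8-fold higher number from compound 2 to compound 4 (0.57 log units; beyond the scatter) as the whole cost of the added propyl. Compound 1 still goes against any rule for branching as such, since a 230-fold lower number from compound 1 to compound 4 (2.36 log units; beyond the scatter) leaves its pentan-3-yl on the high side with the unbranched hexyl of compound 3. Going by these compounds, whether a 1-methyl branch on a still longer chain would stay this low, or an amine on that chain would change the reading, remains open. Nothing shown here accounts for the effect of the 1-methyl branch.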